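An Amide Gives Way to a Triazole

A few compounds are considered here, and "the series" means these few. Any claim that something is new, unique, unknown or untested is made for them only; others in the source may bear on it.

Compound 1, `COc1ccc(C[C@H]2COC(=O)[C@@H]2Cc2ccc(OCC(=O)Nc3ccccc3)c(OC)c2)cc1OC`, is measured in an ADME assay on HeLa cells (Homo sapiens) for cytotoxicity, read by MTT assay (a higher number here means a weaker inhibitor, a lower number a stronger inhibitor), only as a limit of the assay, >= 600000 nM.
Compound 2, `COC(=O)[C@@H](NC(=O)CCC(=O)Oc1ccc(C[C@H]2C(=O)OC[C@@H]2Cc2ccc(OC)c(OC)c2)cc1OC)C(C)C`, gives in this assay a value of 64000 nM.
Compound 3, `COC(=O)[C@H](CC(C)C)NC(=O)CCC(=O)Oc1ccc(C[C@H]2C(=O)OC[C@@H]2Cc2ccc(OC)c(OC)c2)cc1OC`, gives in this assay a value of 53200 nM.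

Among the measured compounds shown here, compound 1 therefore stands at the edge of what the assay reports: it is the one compound sitting at the limit of >= 600000 nM in this assay, at which 1 of the 3 values shown sits, so no number is known for it, only that it is a weak inhibitor of cell growth. For the measured compounds named here, compound 2 and compound 3 are built on the same shared core but differ from compound 1 in another part of the molecule, and the only measured step in hand, a 1.2-fold lower number from compound 2 to compound 3 (0.08 log units; within the scatter), concerns that other part.

Compound 4, `COc1ccc(C[C@H]2COC(=O)[C@@H]2Cc2ccc(OCc3cn(-c4ccccc4)nn3)c(OC)c2)cc1OC`, differs from compound 1 in one place: 1-phenyl-1H-1,2,3-triazol-4-yl in place of phenylcarbamoyl on a saturated chain carbon bound to an oxygen on an aromatic ring. Going by the values given here, no measured step bears on this kind of change, so there is no precedent here for how large a move to expect in this assay, or in which direction.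

Given that compound 1 sits at the limit, compound 4 is expected to remain a weak inhibitor, and the expected step of a number no higher from compound 1 to compound 4 (the limit leaves the size open) is small. Compound 4 is estimated at 600000 nM, with a range from 150000 nM to 2000000 nM.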

Compound 4, half-maximal inhibitory concentration: 124000 nM
Compound 4: the middle estimate sits 4.8-fold (0.68 log units) above what was measured, and the stated range ends above it.
By their numbers in this assay, from the lowest: compounds 3, 2 and 4 (each within the scatter of the next, the first and the last beyond it). At a limit, above all of these: compound 1.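

Replacing phenylcarbamoyl with 1-phenyl-1H-1,2,3-triazol-4-yl on a saturated chain carbon bound to an oxygen on an aromatic ring gives the first readable move at this position in this assay: an at least 4.8-fold lower number from compound 1 to compound 4 (0.68 log units; beyond the scatter). Among the compounds shown here, the earlier compounds could not show this, as their only measured step concerned a different part of the molecule, so this is the first sign that the group at this position can shift the number in this assay. The step gives only the smallest size the change could have, and the real gap may be wider, as compound 1 is held at a limit of the assay rather than a number: the limit of >= 600000 nM in this assay, at which 1 of the 4 values shown sits.

One pair cannot separate the parts of the exchange, such as the new five-membered ring and the loss of the amide hydrogen, and it sets no trend for other groups at this position. A 1-benzyl-1H-1,2,3-triazol-4-yl group, or a triazole whose phenyl ring carries an amine or a carboxylic acid, would show whether the number keeps moving when the group on the triazole changes.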